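Adding a second chloro to compound 3

The source may hold more compounds than are shown below. What is called first, only, known or untested is meant among the compounds shown, and "the series" means these compounds.

In a physicochemical assay for solubility, at pH 7.4 (on this read-out higher numbers stand for higher solubility and lower numbers for lower solubility), compound 1 `Cc1cc(NC(=O)Nc2cccc(F)c2)c2ccccc2n1` reads 100 nM and compound 2 `Cc1cc(NC(=O)Nc2ccc(N)cc2)c2ccccc2n1` reads 18500 nM while compound 3 `Cc1cc(NC(=O)Nc2ccc(Cl)cc2)c2ccccc2n1` stands between them, second highest at 1400 nM on this short series. Compound 4 `Cc1cc(NC(=O)Nc2ccc(Cl)cc2Cl)c2ccccc2n1` carries one change chloro in place of hydrogen on an aromatic carbon from compound 3: chloro in place of hydrogen on an aromatic carbon, ortho to a large group. Going by the values given here, no measured step makes exactly this change. The closest, chloro in place of amino, gave a 13-fold lower number from compound 2 to compound 3 (1.12 log units; beyond the scatter) and was large, whereas 4-chlorophenyl in place of 3-fluorophenyl gave a 14-fold higher number from compound 1 to compound 3 (1.15 log units; beyond the scatter) and was also large. Changes on this ring have therefore moved the number far in both directions, so a moderate fall is expected, with wide doubt. In this assay the expected step is a 2.8-fold lower number from compound 3 to compound 4 (0.45 log units; beyond the scatter) and remains an estimate. The expected value for compound 4 is 500 nM with an estimated range from 120 nM to 1800 nM in this measurement.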

Compound 4, solubility: 100 nM
Compound 4: the middle estimate sits 5.0-fold (0.70 log units) above what was measured, and the stated range ends above it.
By their numbers in this assay, from the lowest: compounds 1 and 4 (each within the scatter of the next); then compound 3; then compound 2.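

In this assay, chloro in place of hydrogen, ortho to a large group, gave a 14-fold lower number from compound 3 to compound 4 (1.15 log units; beyond the scatter). This is the first step shown at this position, and it shows that adding one chlorine atom there, meta to a chloro group, is enough to give a large fall. Nothing measured here accounts for that fall. The compounds shown leave open whether methoxy or a carboxylic acid at this position would give a similar step, and whether the fall depends on the chloro group already present.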